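This account rests on a few compounds, and the source may have more. Where it says the series, first, only, none or still open, it means among the compounds named here.

Compound 1 `COc1cccc(C(=O)Nc2nnc(/C=C/c3cc(OC)c(OC)c(OC)c3Br)s2)c1` gives 170 nM in a functional assay on MCF7 cells (Homo sapiens) for antiproliferative activity, read by MTT assay, with a stated time of 48 h (on this read-out higher numbers stand for weaker inhibition and lower numbers for stronger inhibition), where compound 2 `COc1ccc(C(=O)Nc2nnc(/C=C/c3cc(OC)c(OC)c(OC)c3Br)s2)cc1` gives 560 nM and compound 3 `COc1ccc(/C=C/c2nnc(NC(=O)c3cc(OC)c(OC)c(OC)c3Br)s2)cc1` gives 550 nM. Compound 1 and compound 2 differ by 3-methoxyphenyl in place of 4-methoxyphenyl on a carbonyl carbon, and this change produced a 3.3-fold lower number from compound 2 to compound 1 (0.52 log units; beyond the scatter). The difference between the cores of compound 2 and compound 3 is not broken down here. Compound 4 `COc1cccc(/C=C/c2nnc(NC(=O)c3cc(OC)c(OC)c(OC)c3Br)s2)c1` differs from compound 3 by 3-methoxyphenyl in place of 4-methoxyphenyl on a double-bonded chain carbon bound to a double-bonded chain carbon. For the measured compounds named here, this is the same kind of change as the one from compound 2 to compound 1, but not the same: there the exchanged group sat on a carbonyl carbon whose other neighbours are an amide-type nitrogen, here it sits on a double-bonded chain carbon bound to a double-bonded chain carbon. Because the earlier step gave a 3.3-fold lower number from compound 2 to compound 1 (0.52 log units; beyond the scatter), a step of a 2.2-fold lower number from compound 3 to compound 4 (0.34 log units; beyond the scatter) is expected for compound 4, though somewhat smaller since the surroundings differ. Compound 4 is therefore estimated at 250 nM, expected between 100 nM and 700 nM.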

Compound 4, half-maximal inhibitory concentration: 590 nM
For compound 4 the middle estimate is 2.4-fold (0.37 log units) below the measured one, and the stated range covers the measured number.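

On the core of compound 3, 3-methoxyphenyl in place of 4-methoxyphenyl gave a 1.1-fold higher number from compound 3 to compound 4 (0.03 log units; within the scatter), so this pair cannot be told apart. The exchange therefore did not behave the same way on the two cores: the same change on two cores in this assay, a 3.3-fold lower number (0.52 log units; beyond the scatter) from compound 2 to compound 1 and a 1.1-fold higher number (0.03 log units; within the scatter) from compound 3 to compound 4, 3.5-fold (0.55 log units) apart, beyond the scatter of two such steps

For the compounds shown here, this means that the gain seen on one core cannot be assumed on the other, but with only one pair per core it does not show why the cores differ or how the exchange would behave on a further core. Every compound shown carries a methoxyphenyl group, so it remains open what a fluorophenyl or aminophenyl group would do on either core. Going by these compounds, whether chlorine in place of the shared bromine would alter either result is also open.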